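Adding a Methyl to the Nitrogen of Compound 3

This account rests on a few compounds, and the source may have more. Where it says the series, first, only, none or still open, it means among the compounds named here.

Compound 1 `COc1cc2c3c(n(C)c(=O)c2cc1OC)-c1ccccc1OCC3`: 38100 nM
Compound 2 `COCOc1ccccc1-c1cc2ccccc2c(=O)[nH]1`: 620 nM
Compound 3 `COCOc1ccccc1-c1cc2cc(C)ccc2c(=O)[nH]1`: 170 nM

In a functional assay on HeLa cells (Homo sapiens) for cytotoxicity, read by sulforhodamine B assay (on this read-out higher numbers stand for weaker inhibition and lower numbers for stronger inhibition), compound 3 gives the lowest of the three numbers (170 nM) and so shows the strongest inhibition so far. Compound 4 `COCOc1ccccc1-c1cc2cc(C)ccc2c(=O)n1C` is compound 3 with one change: methyl in place of hydrogen on an aromatic nitrogen. For the measured compounds named here, only one measured step involves a single change, and it offers only indirect guidance: a 3.6-fold lower number from compound 2 to compound 3 (0.56 log units; beyond the scatter) for methyl in place of hydrogen on an aromatic carbon. That methyl sits on a carbon, whereas the new one sits on a nitrogen, so the step's favourable direction need not carry over. Going by the values given here, the only measured compound with a methyl on this nitrogen is compound 1 (at 38100 nM), but it also differs elsewhere, so it offers a cautious hint and no clean comparison. On that hint, a rise beyond the scatter in this assay is expected, meaning weaker inhibition. The expected change is an 8.8-fold higher number from compound 3 to compound 4 (0.95 log units; beyond the scatter) on this evidence. Compound 4 is estimated at 1500 nM with a range from 250 nM to 10000 nM in this wide window.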

Compound 4, half-maximal inhibitory concentration: 28600 nM
For compound 4 the middle estimate is 19-fold (1.28 log units) below the measured one; the whole stated range lies below it.
By their numbers in this assay, from the lowest: compound 3; then compound 2; then compounds 4 and 1 (each within the scatter of the next).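

In this assay, putting a methyl on the aromatic nitrogen in place of the amide hydrogen gives a 170-fold higher number from compound 3 to compound 4 (2.23 log units; beyond the scatter) and so a large loss of inhibition, which marks this nitrogen as a highly sensitive position in the series. The same group on an aromatic carbon had moved the number the other way, with a 3.6-fold lower number from compound 2 to compound 3 (0.56 log units; beyond the scatter) in that step, so in these two steps the outcome of adding a methyl depends on where it sits. Nothing in the data shown explains why the nitrogen methyl costs so much.

The compounds shown leave open whether the loss belongs to methyl itself or would follow any replacement of the amide hydrogen, such as an ethyl group, a longer chain or an acetyl group. Going by these compounds, they also rest on a single step at this nitrogen, so whether the effect holds with other groups elsewhere on the core remains unknown.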